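Removing a Fluoro Group from a Weak Adenosine Ligand

The source may hold more compounds than are shown below. What is called first, only, known or untested is meant among the compounds shown, and "the series" means these compounds.

The study concerns four close relatives built on one shared core. Compound 1 `OCCNc1nc(-c2ccccc2)nc2c1nnn2Cc1ccccc1`, compound 2 `OCCNc1nc(-c2ccccc2)nc2c1nnn2Cc1ccccc1F` and compound 3 `CCNc1nc(-c2ccccc2)nc2c1nnn2Cc1ccccc1F` have been tested, while compound 4 `CCNc1nc(-c2ccccc2)nc2c1nnn2Cc1ccccc1` has not. In an assay on isolated protein for binding affinity to adenosine receptor A1 (Bos taurus) (a lower number here means a stronger inhibitor, a higher number a weaker inhibitor), compound 1 gives 38000000 nM. In this assay compound 2 gives 54000000 nM and compound 3 gives 11000000 nM.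

Compound 2 and compound 1 differ by hydrogen in place of fluoro on an aromatic carbon, and that change produced a 1.4-fold lower number from compound 2 to compound 1 (0.15 log units; within the scatter). Compound 2 and compound 3 differ by hydrogen in place of hydroxy on a saturated chain carbon, two bonds along the chain from a nitrogen on an aromatic ring, with the larger effect of a 4.9-fold lower number from compound 2 to compound 3 (0.69 log units; beyond the scatter). Compound 3 thus shows the lowest number of the three measured, with compound 1 and compound 2 above it.

Compound 4 differs from compound 3 by hydrogen in place of fluoro on an aromatic carbon, the same change that separates compound 2 from compound 1, the two pairs differing in their cores by hydrogen in place of hydroxy on a saturated chain carbon, two bonds along the chain from a nitrogen on an aromatic ring. Because that earlier change gave a 1.4-fold lower number from compound 2 to compound 1 (0.15 log units; within the scatter), a step within the scatter, the expected step here is small, estimated as a 1.4-fold lower number from compound 3 to compound 4 (0.14 log units; within the scatter). Going by the values given here, the one prior example provides thin support, so the range around the estimate is kept wide. On this basis compound 4 is expected to give about 8000000 nM in this assay, most likely between 3000000 nM and 25000000 nM.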

Compound 4, inhibition constant: 91000000 nM
Compound 4: middle estimate off by 11-fold (1.06 log units), on the low side, outside the stated range (above it).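

In this assay, replacing fluoro with hydrogen on the aromatic carbon gave an 8.3-fold higher number from compound 3 to compound 4 (0.92 log units; beyond the scatter), and replacing hydroxy with hydrogen on the chain carbon gave a 2.4-fold higher number from compound 1 to compound 4 (0.38 log units; beyond the scatter), so the fluoro change did not carry over from the hydroxy-bearing compounds to those without the hydroxy group: the same change on two cores in this assay, a 1.4-fold lower number (0.15 log units; within the scatter) from compound 2 to compound 1 and an 8.3-fold higher number (0.92 log units; beyond the scatter) from compound 3 to compound 4, 12-fold (1.07 log units) apart, beyond the scatter of two such steps The hydroxy change, read across the same four compounds, likewise depends on whether the fluoro group is present: the same change on two cores in this assay, a 4.9-fold lower number (0.69 log units; beyond the scatter) from compound 2 to compound 3 and a 2.4-fold higher number (0.38 log units; beyond the scatter) from compound 1 to compound 4, 12-fold (1.07 log units) apart, beyond the scatter of two such steps These two comparisons are one square of four compounds seen from two sides, so they show that in this small set the effect of each change depended on the other, but they do not show why, nor how either change would behave on any other core.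

The compounds shown leave open whether this dependence is tied to the hydroxy group itself or would also appear with an amine or a carboxylic acid at the end of the chain, or with a longer chain. They also leave open whether chloro or methoxy in the place of the fluoro group would follow compound 3 or compound 2 in its step to the unsubstituted benzyl.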